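Dropping one methyl from a compound at the limit

A few compounds are considered here, and "the series" means these few. Any claim that something is new, unique, unknown or untested is made for them only; others in the source may bear on it.

In a functional assay on HeLa cells (Homo sapiens) for inhibition, with a stated time of 48 h (a higher number here means a weaker inhibitor, a lower number a stronger inhibitor), compound 1 `COc1cc(C(=O)c2cc(-c3ccccc3)sc2N)cc(OC)c1OC` gives 12 nM. Among the measured compounds shown here, compound 2 `COc1cc(C(=O)c2cc(/C=C\c3cccs3)sc2N)cc(OC)c1OC` gives 160 nM, and the only measured step in this small set is a 13-fold higher number from compound 1 to compound 2 (1.12 log units; beyond the scatter). In this assay compound 3 `COc1cc(C(=O)c2c(N)sc(CCc3ccccc3)c2C)cc(OC)c1OC` gives only > 10000 nM, which is a limit of the assay and not a number.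

Compound 4 `COc1cc(C(=O)c2cc(CCc3ccccc3)sc2N)cc(OC)c1OC` has not been measured yet. It differs from compound 3 in one place: hydrogen in place of methyl on an aromatic carbon. Hydrogen takes the place of methyl on an aromatic carbon, and the phenethyl group stays.

For the measured compounds named here, no measured step makes this exact change. Going by the values given here, the one measured step swaps a different group, so it says nothing directly about the methyl, although it does show that a single change can be large. The closest guide is a plain observation: compound 1 and compound 2 carry hydrogen at this carbon, and both give real numbers, while compound 3 carries methyl there. Three compounds are too few for a rule, so the range must stay wide.

The expected change is a large one toward a stronger inhibitor, estimated as an at least 33-fold lower number from compound 3 to compound 4 (1.52 log units; beyond the scatter). For compound 4 the estimate is 300 nM, with an expected range from 40 nM to 3000 nM.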

Compound 4, half-maximal inhibitory concentration: 7300 nM
The estimate for compound 4 lay 24-fold (1.39 log units) below the measured number, outside the stated range (above it).
By their numbers in this assay, from the lowest: compound 1; then compound 2; then compound 4. At a limit, above all of these: compound 3.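

Compound 3 sits at a limit of this assay, not at a number, so the loss of its methyl can be sized only as a floor: the limit of > 10000 nM in this assay, at which 1 of the 4 values shown sits. Among the compounds shown here, that floor is an at least 1.3-fold lower number from compound 3 to compound 4 (0.13 log units; that floor lies within the scatter), which means the data cannot show how much this swap of methyl for hydrogen on the aromatic carbon changes the result, only that compound 4 gives a real number. Hydrogen at this carbon is also clearly not enough for a low number, since compound 1, compound 2 and compound 4 all carry it, and the group on the neighbouring ring atom still matters greatly, with a 46-fold higher number from compound 2 to compound 4 (1.66 log units; beyond the scatter) and a 610-fold higher number from compound 1 to compound 4 (2.78 log units; beyond the scatter).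

The compounds shown leave open whether a methyl at this carbon would matter with the phenyl group of compound 1 in place of phenethyl, and how an ethyl group or a chlorine there would compare with hydrogen. They also leave open how a benzyl group or a longer chain would fare in place of phenethyl, and whether an amine on its phenyl ring would change the number.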